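Swapping the anilide aryl group on a thiazolidinedione-type HDAC4 inhibitor

The source may report more compounds than this note shows. Statements on the series, on what has been measured and on what is new or still open speak of the compounds shown alone.

The measured compounds and their values:

Compound 1, `Cc1cccc(NC(=O)COc2ccc3cc(/C=C4/SC(=O)NC4=O)ccc3c2)n1`, gives 1100 nM.
Compound 2, `COc1cccc(NC(=O)COc2ccc3cc(/C=C4/SC(=O)NC4=O)ccc3c2)c1`, gives 1600 nM.
Compound 3, `O=C(COc1ccc2cc(/C=C3/SC(=O)NC3=O)ccc2c1)Nc1ccccc1Oc1ccccc1`, gives 5200 nM.

All three share the same core and differ only in the aryl group carried on the amide-type nitrogen. In an assay on isolated protein for inhibition of histone deacetylase 4 (Homo sapiens), with a stated time of 1 h (on this read-out higher numbers stand for weaker inhibition and lower numbers for stronger inhibition), compound 2 stands second highest of the three numbers: its nearest neighbour is compound 1, and the step of a 1.5-fold higher number from compound 1 to compound 2 (0.16 log units; within the scatter) is within the scatter, while compound 3 lies furthest away, with a number beyond the scatter above that of compound 2.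

Compound 4, `O=C(COc1ccc2cc(/C=C3/SC(=O)NC3=O)ccc2c1)Nc1ccc(Cl)c(Cl)c1`, has not been measured. It differs from compound 2 in one place: 3,4-dichlorophenyl in place of 3-methoxyphenyl on an amide-type nitrogen. For the measured compounds named here, no measured step covers this particular exchange. Going by the values given here, the only step involving compound 2, a 1.5-fold higher number from compound 1 to compound 2 (0.16 log units; within the scatter), shows that one small aryl group replacing another on this nitrogen moved the number little; compound 3, with a larger group, gave the higher number. For compound 4 the step of a 1.1-fold lower number from compound 2 to compound 4 (0.03 log units; within the scatter) is therefore expected to stay within the scatter, with no clear direction. Compound 4 is expected to give about 1500 nM, in the range 500 nM to 5000 nM.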

Compound 4, half-maximal inhibitory concentration: 5500 nM
Estimate against measurement, compound 4: 3.7-fold (0.56 log units) below; measured number above the stated range.
By their numbers in this assay, from the lowest: compounds 1 and 2 (each within the scatter of the next); then compounds 3 and 4 (each within the scatter of the next).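

In this assay, the step of a 3.4-fold higher number from compound 2 to compound 4 (0.54 log units; beyond the scatter) shows that exchanging one aryl group for another on this amide-type nitrogen can move the number beyond the scatter, even though 3-methoxyphenyl and 3,4-dichlorophenyl both count 8 heavy atoms. The step of a 5.0-fold higher number from compound 1 to compound 4 (0.70 log units; beyond the scatter) is likewise beyond the scatter, and the 3,4-dichlorophenyl group lands level with the aryl group of compound 3: compound 3 gives 5200 nM and compound 4 gives 5500 nM, values within the scatter of each other. Nothing at hand accounts for these steps.

On these data alone, it remains open whether the step to compound 4 belongs to the two chlorine atoms or to the loss of the methoxy group, and how a phenyl group with a single chlorine would read on this nitrogen. Also open, as far as these compounds go, is how an aryl group carrying an amine or a carboxylic acid would read here.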